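Halogen Exchange on the Methylphenyl Ring of Compound 1

A few compounds are considered here, and "the series" means these few. Any claim that something is new, unique, unknown or untested is made for them only; others in the source may bear on it.

Measured compounds:
compound 1, `Cc1ccc(S(=O)(=O)c2cnc3cc(F)ccc3c2N2CCC(C)CC2)cc1Cl`, 93%
compound 2, `Cc1ccc(S(=O)(=O)c2cnc3cc(Cl)ccc3c2N2CCC(C)CC2)cc1Cl`, 89%

In an assay on isolated protein for displacement of a labelled ligand from metabotropic glutamate receptor 5 (Homo sapiens), with a stated time of 60 min, tested at 1 uM (a higher number here means more inhibition at the concentration tested (going by the name of the read-out), a lower number less inhibition), compound 1 gives 93%, which is the top of the two numbers recorded, though its gap to compound 2 is within the scatter. Compound 2 gives 89% in this assay; the step of a number 4 percentage points lower from compound 1 to compound 2 (within the scatter), arising from chloro in place of fluoro on an aromatic carbon, is within the scatter, so the two compounds cannot be ranked. Compound 3, `Cc1ccc(S(=O)(=O)c2cnc3cc(F)ccc3c2N2CCC(C)CC2)cc1F`, differs from compound 1 by fluoro in place of chloro on an aromatic carbon. For the measured compounds named here, the only measured step that bears on it is a number 4 percentage points lower from compound 1 to compound 2 (within the scatter), a halogen exchange elsewhere on the shared core that changed nothing beyond the scatter. On that basis no step beyond the scatter is expected in this assay, with any drift estimated as slightly downward, a number 5 percentage points lower from compound 1 to compound 3 (within the scatter). Compound 3 is therefore estimated at 88%, in the range 74% to 96%.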

Compound 3, a percentage reported as inhibition, at one concentration (the size of the read-out at that concentration, not a potency): 89%
Estimate against measurement, compound 3: 1 percentage points below; measured number inside the range.
By their numbers in this assay, from the lowest: compounds 2, 3 and 1 (each within the scatter of the next).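

In this assay, the change from 3-chloro-4-methylphenyl to 3-fluoro-4-methylphenyl gives a number 4 percentage points lower from compound 1 to compound 3 (within the scatter). The earlier compounds had shown a halogen exchange only elsewhere on the shared core, so this is the first reading at this position, ortho to a methyl group, and it shows that chloro and fluoro cannot be told apart here at the one concentration tested. Nothing available explains this result or bears on how the two halogens act at this position.

The compounds shown leave open whether a group other than a halogen, such as methoxy, nitrile or a bare hydrogen, would keep this level of inhibition at the same position. They also leave open whether chloro and fluoro would separate in a full potency measurement.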